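The source may hold more compounds than are shown below. What is called first, only, known or untested is meant among the compounds shown, and "the series" means these compounds.

In a functional assay on A549 cells (Homo sapiens) for cytotoxicity, read by colorimetric assay and MTT assay (a higher number here means a weaker inhibitor, a lower number a stronger inhibitor), compound 1 (`COc1ccc2cc(-c3ccccc3)c(O)nc2c1`) gives 10000 nM and compound 2 (`CCN(CC)C(=O)Cn1c(=O)c(-c2ccc(OC)cc2)cc2c(OC)cc(OC)cc21`) gives 10000 nM in the same read-out, so compound 2 stands level with compound 1, within the scatter. Compound 3 (`COc1ccc(-c2cc3c(OC)cc(OC)cc3n(CC(=O)OCc3ccccc3)c2=O)cc1`) keeps the rest of compound 2 and carries benzyloxy in place of diethylamino on a carbonyl carbon, so that diethylcarbamoyl becomes benzyloxycarbonyl. Among the compounds with values here, no measured pair shows what such a swap does. The expectation therefore rests only on the two readings in hand, compound 1 at 10000 nM and compound 2 at 10000 nM with no gap between them at the digits shown. The expected step is no change at the digits printed from compound 2 to compound 3 (within the scatter) and is estimated to stay within the scatter, with neither direction favoured. For compound 3 the estimate is 10000 nM with an expected range from 3000 nM to 30000 nM for the half-maximal inhibitory concentration.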

Compound 3, half-maximal inhibitory concentration: 10000 nM
Compound 3: middle estimate and measured number agree at the digits printed, and the stated range covers the measured number.
By their numbers in this assay, from the lowest: compounds 1, 2 and 3 (each within the scatter of the next).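

In this assay, within the data shown here, the first swap that can be read at this carbonyl carbon gives no change at the digits printed from compound 2 to compound 3 (within the scatter). Benzyloxy brings a six-membered aromatic ring of carbon only and a hydrogen-bond acceptor that diethylamino lacks, yet the two readings do not separate, so amide and ester forms of this side chain are not told apart here. No measurement at hand accounts for this result.

Still open, going by these compounds, is whether a carboxylic acid or a primary amide on this carbonyl carbon, or a longer chain in place of the (benzyloxycarbonyl)methyl group, would give a reading that separates from those of compound 2 and compound 3. A single step at this place also sets no trend for other groups there.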